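The compounds below may be only part of what the source reports. "The series", "measured", "known", "first", "only" and "open" are said of these compounds alone.

Compound 1 `CC(C(=O)NCc1ccc(C(F)(F)F)nc1-c1ccccc1)c1ccc(NS(C)(=O)=O)c(F)c1` is the starting point of this account. For the measured compounds named here, in an assay on CHO cells for antagonist activity at transient receptor potential cation channel subfamily V member 1 (Homo sapiens), read by FLIPR (a higher number here means a weaker inhibitor, a lower number a stronger inhibitor), compound 1 gives 6.4 nM, which is the highest of the three numbers measured so far. Compound 2 `CC(C(=O)NCc1ccc(C(F)(F)F)nc1-c1ccc(N(C)C)cc1)c1ccc(NS(C)(=O)=O)c(F)c1` gives 3.2 nM in this assay, and compound 3 `Cc1cc(-c2nc(C(F)(F)F)ccc2CNC(=O)C(C)c2ccc(NS(C)(=O)=O)c(F)c2)ccc1F` gives 0.4 nM in this assay. The step of a 2.0-fold lower number from compound 1 to compound 2 (0.30 log units; within the scatter) lies within the scatter, whereas the step of a 16-fold lower number from compound 1 to compound 3 (1.20 log units; beyond the scatter) is large and beyond it, and the step of an 8.0-fold lower number from compound 2 to compound 3 (0.90 log units; beyond the scatter) is modest.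

Compound 4 `COc1ccc(-c2nc(C(F)(F)F)ccc2CNC(=O)C(C)c2ccc(NS(C)(=O)=O)c(F)c2)cc1F` has not yet been measured. It differs from compound 1 in one place: 3-fluoro-4-methoxyphenyl in place of phenyl on an aromatic carbon. Both measured steps from compound 1 concern the same aromatic carbon: the exchange of phenyl for 4-(dimethylamino)phenyl moved the number only within the scatter, while the exchange for 4-fluoro-3-methylphenyl brought a large fall. A 3-fluoro-4-methoxyphenyl group is nearer in kind to the 4-fluoro-3-methylphenyl of compound 3 than to the unsubstituted phenyl of compound 1, and a fall in this assay beyond the scatter is therefore expected. Going by the values given here, no measured compound carries this exact group, and the expected fall is set smaller than that seen with compound 3. Compound 4 is thus expected to give 1.5 nM in this assay, with a range from 0.5 nM to 5 nM. The expected step is a 4.3-fold lower number from compound 1 to compound 4 (0.63 log units; beyond the scatter).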

Compound 4, inhibition constant: 4.2 nM
For compound 4 the middle estimate is 2.8-fold (0.45 log units) below the measured one; low and high end bracket the measured number.
By their numbers in this assay, from the lowest: compound 3; then compounds 2, 4 and 1 (each within the scatter of the next).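

In this assay the step is a 1.5-fold lower number from compound 1 to compound 4 (0.18 log units; within the scatter), and the step to the dimethylamino analogue is a 1.3-fold higher number from compound 2 to compound 4 (0.12 log units; within the scatter), so a substituted phenyl at this position does not in itself bring the gain: 3-fluoro-4-methoxyphenyl stands within the scatter of both the unsubstituted phenyl and 4-(dimethylamino)phenyl. The fall seen earlier therefore belongs to 4-fluoro-3-methylphenyl in particular and not to fluoro-bearing phenyl groups in general, as the step of an 11-fold higher number from compound 3 to compound 4 (1.02 log units; beyond the scatter) shows, even though the two groups both carry a fluoro and one further substituent. The information available offers no explanation for this sharp difference between two such similar groups.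

As far as these compounds go, what remains open is which part of the exchange counts, since compound 3 and compound 4 differ both in methyl against methoxy and in where the fluoro sits; a 4-fluoro-3-methoxyphenyl or a 3-fluoro-4-methylphenyl group would separate the two. Also open, from the compounds shown here alone, is whether a single substituent, as in 4-fluorophenyl or 3-methylphenyl, already accounts for the low number of compound 3 0.4 nM.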